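The source may hold more compounds than are shown below. What is called first, only, known or untested is meant among the compounds shown, and "the series" means these compounds.

Measured compounds:
compound 1 `O=[N+]([O-])c1ccc(S(=O)(=O)Nc2nccc3ccccc23)cc1`, compound 2 `O=S(=O)(Nc1nccc2ccccc12)c1ccc(Cl)cc1`, compound 3 `Cc1cc2cc(NS(=O)(=O)c3ccc([N+](=O)[O-])cc3)ccc2[nH]1`.

In an ADME assay on J774 cells (Mus musculus) for cytotoxicity, read by fluorescence and resazurin assay, with a stated time of 24 h (on this read-out lower numbers stand for higher toxicity in this test and higher numbers for lower toxicity in this test), compound 1 gives 41300 nM. For compound 2 the value is a limit of the assay, >= 300000 nM. Compound 3 gives 132000 nM in this assay. The change chloro in place of nitro on an aromatic carbon produced an at least 7.2-fold higher number from compound 1 to compound 2 (0.86 log units; beyond the scatter), a step whose size is bounded by the limit of >= 300000 nM in this assay, at which 1 of the 3 values shown sits. The cores of compound 1 and compound 3 differ, but that difference is not broken down here. Compound 4 `Cc1cc2cc(NS(=O)(=O)c3ccc(Cl)cc3)ccc2[nH]1` is not yet measured; it arises from compound 3 by chloro in place of nitro on an aromatic carbon, the same change made from compound 1 to compound 2. Because compound 3 already stands at 132000 nM, and because the earlier change produced an at least 7.2-fold higher number from compound 1 to compound 2 (0.86 log units; beyond the scatter), compound 4 is expected to give a higher number, with an estimated 2.3-fold higher number from compound 3 to compound 4 (0.36 log units; beyond the scatter). The estimate for compound 4 in this assay is 300000 nM, between 150000 nM and 1000000 nM.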

Compound 4, half-maximal cytotoxic concentration: 195000 nM
The estimate for compound 4 lay 1.5-fold (0.19 log units) above the measured number, within the range that was stated.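

In this assay, chloro in place of nitro on the second core gave a 1.5-fold higher number from compound 3 to compound 4 (0.17 log units; within the scatter), so the change did not carry over from one core to the other with the same size: the same change on two cores in this assay, an at least 7.2-fold higher number (0.86 log units; beyond the scatter) from compound 1 to compound 2 and a 1.5-fold higher number (0.17 log units; within the scatter) from compound 3 to compound 4, at least 4.9-fold (0.69 log units) apart, beyond the scatter of two such steps. The value of compound 2 is a limit of the assay, so the earlier step gives only a bound and not a true size: the limit of >= 300000 nM in this assay, at which 1 of the 4 values shown sits. These two pairs do not show why the cores differ in this respect, or how the change would behave on any further core.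

The compounds shown leave open what an amine or a carboxylic acid in place of nitro on that aromatic carbon would give on either core.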